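The source may hold more compounds than are shown below. What is called first, only, known or untested is meant among the compounds shown, and "the series" means these compounds.

Measured compounds:
compound 1 `COc1cc(NC(=O)Nc2cc(Nc3cccc(C(C)(C)C)c3)ncn2)cc(OC)c1` gives 48.7% in a functional assay on HCC827 cells (Homo sapiens) for inhibition, read by MTT assay, with a stated time of 48 h, tested at 10 uM; on this read-out higher numbers stand for more inhibition at the one concentration tested (going by the name of the read-out) and lower numbers for less inhibition;
compound 2 `COc1cc(NC(=O)Nc2cc(Nc3cc(C(F)(F)F)ccc3OC)ncn2)cc(OC)c1` gives 59.7% in this assay;
compound 3 `COc1cc(NC(=O)Nc2cc(Nc3ccc(Br)cc3OC)ncn2)cc(OC)c1` gives 57.7% in this assay.

On these numbers compound 3 stands second highest of the three. Its nearest neighbour is compound 2, which lies within the scatter of it, and its furthest is compound 1, which also lies within the scatter. Going by the values given here, the only single-place step measured so far, a number 9 percentage points higher from compound 1 to compound 3 (within the scatter), falls within the scatter as well.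

Compound 4 `COc1cc(NC(=O)Nc2cc(Nc3cc(Br)ccc3OC)ncn2)cc(OC)c1` is not yet measured in this assay. It differs from compound 3 in one place: 5-bromo-2-methoxyphenyl in place of 4-bromo-2-methoxyphenyl on a nitrogen on an aromatic ring. Among the compounds with values here, no measured step changes the position of a bromine on this ring, so nothing measured bears directly on this change. Compound 2, which also carries a group on the 5-position of a 2-methoxyphenyl, gives 59.7%, and all three measured values sit within the scatter of one another. Compound 4 is therefore expected to show a step of a number 0.3 percentage points higher from compound 3 to compound 4 (within the scatter), none beyond the scatter. Compound 4 is estimated at 58%, between 45% and 70%.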

Compound 4, a percentage reported as inhibition, at one concentration (the size of the read-out at that concentration, not a potency): 76.3%
Compound 4: the middle estimate sits 18.3 percentage points below what was measured, and the stated range ends below it.
By their numbers in this assay, from the lowest: compounds 1, 3 and 2 (each within the scatter of the next, the first and the last beyond it); then compound 4.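

In this assay, going by these compounds alone, moving the bromine alone, with the same atoms joined differently, gives a number 18.6 percentage points higher from compound 3 to compound 4 (beyond the scatter) and so shows that the place of the bromine on this ring counts, which no earlier step could show. Bromo in place of trifluoromethyl on an aromatic carbon gives a number 16.6 percentage points higher from compound 2 to compound 4 (beyond the scatter) and so shows that the 5-bromo-2-methoxyphenyl group is not matched by its trifluoromethyl counterpart. Set against the 3-(tert-butyl)phenyl group, the same group gives a number 27.6 percentage points higher from compound 1 to compound 4 (beyond the scatter) as the largest step shown.

From the compounds shown here alone, what a chloro, amino or nitrile group would give in place of the bromo on the 5-bromo-2-methoxyphenyl group remains open. Nothing shown gives a reason for any of these steps.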